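From Halogenated Aryl to Dimethylphenyl: Stability Expected to Return

A few compounds are considered here, and "the series" means these few. Any claim that something is new, unique, unknown or untested is made for them only; others in the source may bear on it.

Measured so far in an ADME assay on microsomes from liver (Rattus norvegicus) for metabolic stability, read by LC-MS, using NADPH, at 37 degrees C; on this read-out higher numbers stand for a longer-lived compound and lower numbers for a shorter-lived compound:
- compound 1 `Cc1cc(C)c(-c2nc(CN3CCC(C(=O)NCCCN4C[C@H](C)C[C@H](C)C4)CC3)c(C)o2)c(C)c1`, for which compound 1 gives > 0.5 h, a limit of the assay rather than a number
- compound 2 `Cc1oc(-c2c(Cl)cccc2Br)nc1CN1CCC(C(=O)NCCCN2C[C@H](C)C[C@H](C)C2)CC1`, for which compound 2 gives 0.0233 h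
- compound 3 `Cc1ccccc1-c1nc(CN2CCC(C(=O)NCCN3C[C@H](C)C[C@H](C)C3)CC2)c(C)o1`, for which compound 3 gives > 0.5 h, again a limit of the assay

Compound 2 is thus the only one of the three with an actual number; the other two sit at the limit of > 0.5 h in this assay, at which 2 of the 3 values shown sit. Among the measured compounds shown here, the one step that can be read directly is an at least 21-fold lower number from compound 1 to compound 2 (1.33 log units; beyond the scatter), where the halogenated ring replaced the 2,4,6-trimethylphenyl group.

The next compound, compound 4 `Cc1cccc(C)c1-c1nc(CN2CCC(C(=O)NCCCN3C[C@H](C)C[C@H](C)C3)CC2)c(C)o1`, returns in the other direction: 2,6-dimethylphenyl in place of 2-bromo-6-chlorophenyl on an aromatic carbon. The measured step from compound 1 to compound 2 bears on it, since it pairs the same 2-bromo-6-chlorophenyl with a methylated phenyl, and that step was large. A step of similar size, upward, is therefore expected in this assay, with the likely outcome that compound 4 again reaches the limit rather than a number. Compound 4 is accordingly estimated at 0.5 h, within 0.15 h to 1.5 h, which corresponds to an expected step of a 21-fold higher number from compound 2 to compound 4 (1.33 log units; beyond the scatter).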

Compound 4, half-life: 0.0517 h
Beside the measured number, compound 4's estimate is 9.7-fold (0.99 log units) above it; measured number below the stated range.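

In this assay, among the compounds shown here, the exchange at this aromatic carbon of the five-membered ring proves smaller than the earlier compounds suggested: replacing 2-bromo-6-chlorophenyl with 2,6-dimethylphenyl gives a 2.2-fold higher number from compound 2 to compound 4 (0.35 log units; beyond the scatter). Swapping the halogens for methyl groups therefore does not by itself restore the longer half-life, and the larger step lies elsewhere on the same phenyl ring, where hydrogen in place of methyl on an aromatic carbon, turning 2,4,6-trimethylphenyl into 2,6-dimethylphenyl, gives an at least 9.6-fold lower number from compound 1 to compound 4 (0.98 log units; beyond the scatter). Compound 1 gives > 0.5 h, which is a limit of the assay, and the true size of that step stays open at its upper end: the limit of > 0.5 h in this assay, at which 2 of the 4 values shown sit.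

The compounds shown leave open whether the methyl group itself is needed at the place where compound 1 carries it and compound 4 carries hydrogen, or whether a chlorine, a fluorine or a methoxy group there would serve as well. They also leave open whether that same methyl group, added to the 2-bromo-6-chlorophenyl ring of compound 2, would give a comparable step in the half-life.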